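The source may hold more compounds than are shown below. What is called first, only, known or untested is meant among the compounds shown, and "the series" means these compounds.

Working notes on the series. In an ADME assay on microsomes from liver (Homo sapiens) for metabolic stability, with a stated time of 60 min, tested at 1 uM (on this read-out higher numbers stand for a more stable compound and lower numbers for a less stable compound), compound 1 `CNc1nc2c(-c3ccnc(OC)c3)cnn2cc1OC` gives 63%, the highest of the three numbers in hand. Compound 3 `COc1cn2ncc(-c3ccnc(OC4CC4)c3)c2nc1-c1cnn(C)c1` gives 47%. Compound 2 `COc1cn2ncc(-c3ccnc(OC(C)C)c3)c2nc1-c1cnn(C)c1` gives 32%. Both sit lower than compound 1, beyond the scatter.

Compound 4 `COc1cc(-c2cnn3cc(OC)c(N(C)C)nc23)ccn1` has not yet been measured. It differs from compound 1 by methyl in place of hydrogen on a nitrogen on an aromatic ring, which reads as methylamino to dimethylamino.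

Among the measured compounds shown here, only one measured step changes a single place, a number 15 percentage points higher from compound 2 to compound 3 (beyond the scatter). This modest step has cyclopropyl in place of isopropyl on an oxygen on an aromatic ring, so it bears only indirectly on the new change. For the measured compounds named here, no measured pair varies the group on the nitrogen. That step is therefore used as a guide to size alone, and a shift of similar modest size is expected in this assay. The direction is tentative, with a downward move favoured since compound 1 holds the top number of the set at 63%. The expected change is a number 13 percentage points lower from compound 1 to compound 4 (beyond the scatter), and a result within the scatter cannot be excluded. For compound 4 the estimated value is 50%, with an expected range of 32% to 68%.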

Compound 4, percent of the compound remaining: 16%
Compound 4: the middle estimate sits 34 percentage points above what was measured; measured number below the stated range.
By their numbers in this assay, from the lowest: compound 4; then compound 2; then compound 3; then compound 1.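

In this assay, the nitrogen on an aromatic ring proves to be a sensitive place in the series: going from methylamino to dimethylamino gives a number 47 percentage points lower from compound 1 to compound 4 (beyond the scatter), although the entering methyl adds only 1 heavy atom. Among the compounds shown here, the only earlier single-place step, a number 15 percentage points higher from compound 2 to compound 3 (beyond the scatter), concerns the group on an oxygen on an aromatic ring, so this is the first reading at the nitrogen, and it shows a downward move larger than that modest step. No measurement in hand bears on what lies behind the drop, and it stays without an assigned cause.

Only methylamino and dimethylamino are compared at this nitrogen, which leaves open whether the drop is specific to a second methyl or extends to other groups in that place. An ethyl group or a longer chain on the same nitrogen, in place of the added methyl, would show whether the read-out falls further, holds or recovers with the size of the entering group.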